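Replacing the carbamoyl pyridine with a pyrrolidinone

The source may hold more compounds than are shown below. What is called first, only, known or untested is meant among the compounds shown, and "the series" means these compounds.

Compound 3 `CNC(=O)c1ccc(-c2cnc(NCc3c(F)ccc4c3CCO4)c3cn[nH]c(=O)c23)c(C)n1` stands highest of the three measured compounds in a physicochemical assay for solubility, read by LC-MS, in phosphate buffer, with a stated time of 24 h, at pH 7.4 (a lower number here means a less soluble compound, a higher number a more soluble compound), where compound 3 gives 19000 nM. Compound 1 `Cc1cc(-c2cnc(NCc3c(F)ccc4c3CCO4)c3cn[nH]c(=O)c23)n(C)n1` gives 1000 nM and compound 2 `Cn1cc(-c2cnc(NCc3c(F)ccc4c3CCO4)c3cn[nH]c(=O)c23)cn1` gives 1000 nM, with no change at the digits printed from compound 1 to compound 2 (within the scatter). The two steps into compound 3 were large: a 19-fold higher number from compound 1 to compound 3 (1.28 log units; beyond the scatter) and a 19-fold higher number from compound 2 to compound 3 (1.28 log units; beyond the scatter). Compound 4 `O=C1CCCN1c1cnc(NCc2c(F)ccc3c2CCO3)c2cn[nH]c(=O)c12` differs from compound 3 as follows: 2-oxopyrrolidin-1-yl in place of 2-methyl-6-(methylcarbamoyl)pyridin-3-yl on an aromatic carbon. Among the measured compounds shown here, no measured step involves the group that enters, so the only guide is that the group leaving compound 3 accompanied a large rise from compound 1 and compound 2. Compound 4 is therefore expected to fall back toward those two, with a 6.3-fold lower number from compound 3 to compound 4 (0.80 log units; beyond the scatter) estimated, giving a solubility of 3000 nM with a range from 800 nM to 12000 nM.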

Compound 4, solubility: < 2000 nM
Compound 4 gave a limit, no number; the forecaster's own chance of this, stated with the estimate: 5%; middle value at least 1.5-fold (0.17 log units) from the limit.
By their numbers in this assay, from the lowest: compounds 1 and 2 (each within the scatter of the next); then compound 3.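

Compound 4 gives only a limit in this assay, not a number: the limit of < 2000 nM in this assay, at which 1 of the 4 values shown sits. Even so, 2-oxopyrrolidin-1-yl in place of 2-methyl-6-(methylcarbamoyl)pyridin-3-yl gives an at least 9.5-fold lower number from compound 3 to compound 4 (0.97 log units; beyond the scatter), so a non-aromatic lactam ring at this position does not keep the high number of compound 3. Going by these compounds, the steps from compound 1 and compound 2 to compound 4 cannot be read, so its order against those two stays unknown.

The compounds shown do not separate the methylcarbamoyl group from its pyridine ring. They also leave open how an amine or a carboxylic acid at this position would read.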